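Aryl swap from compound 3 to compound 4

The source may hold more compounds than are shown below. What is called first, only, known or untested is meant among the compounds shown, and "the series" means these compounds.

In a functional assay on MCF7 cells (Homo sapiens) for antiproliferative activity, read by MTT assay, with a stated time of 72 h (on this read-out lower numbers stand for stronger inhibition and higher numbers for weaker inhibition), compound 1 `CCOc1ccc(-c2ccc3ncn(-c4cc(OC)c(OC)c(OC)c4)c3c2)cc1` gives 1710 nM and compound 2 `COc1cc(-n2cnc3ccc(-c4ccc(C(C)=O)cc4)cc32)cc(OC)c1OC` gives 1540 nM as its reading. The step between these two is a 1.1-fold lower number from compound 1 to compound 2 (0.05 log units; within the scatter) and sets no order between them. Compound 3 `COc1ccc(-c2ccc3ncn(-c4cc(OC)c(OC)c(OC)c4)c3c2)cc1F` stands lowest of the three at 520 nM on this read-out.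

Compound 4 `COc1cc(-n2cnc3ccc(-c4ccc([N+](=O)[O-])cc4)cc32)cc(OC)c1OC` is still unmeasured. It differs from compound 3 as follows: 4-nitrophenyl in place of 3-fluoro-4-methoxyphenyl on an aromatic carbon with 4-nitrophenyl in place of 3-fluoro-4-methoxyphenyl on an aromatic carbon.

The most relevant evidence is the pair of steps that replace this same aryl group and arrive at compound 3 (a 3.3-fold lower number from compound 1 to compound 3 (0.52 log units; beyond the scatter) and a 3.0-fold lower number from compound 2 to compound 3 (0.47 log units; beyond the scatter)). Both are modest. Compound 4 lacks the fluorine of compound 3, as do compound 1 and compound 2. For the measured compounds named here, no measured compound carries 4-nitrophenyl, so the transfer is uncertain. A modest rise is therefore expected, about as large as those two steps or somewhat smaller, and in the reverse direction.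

The step expected in this assay is a 2.5-fold higher number from compound 3 to compound 4 (0.40 log units; beyond the scatter) and it runs toward weaker inhibition. For compound 4 the estimated value is 1300 nM with an expected range of 550 nM to 3000 nM on this read-out.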

Compound 4, half-maximal inhibitory concentration: 740 nM
Compound 4: the middle estimate sits 1.8-fold (0.24 log units) above what was measured, within the range that was stated.
By their numbers in this assay, from the lowest: compounds 3 and 4 (each within the scatter of the next); then compounds 2 and 1 (each within the scatter of the next).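

In this assay, 4-nitrophenyl in place of 3-fluoro-4-methoxyphenyl gives a 1.4-fold higher number from compound 3 to compound 4 (0.15 log units; within the scatter) and so cannot be told apart from compound 3 on this read-out, which shows that a reading in this range at this position does not depend on the fluorine, as compound 4 carries none. Nitro in place of acetyl gives a 2.1-fold lower number from compound 2 to compound 4 (0.32 log units; beyond the scatter) and nitro in place of ethoxy gives a 2.3-fold lower number from compound 1 to compound 4 (0.36 log units; beyond the scatter), both modest steps, so the single group on this phenyl ring does move the reading, although compound 1 and compound 2 could not be separated from each other. No measurement shown bears on why the reading shifts with these aryl groups.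

The separate contribution of the fluorine in compound 3 remains open, since no compound shown pairs 3-fluoro-4-methoxyphenyl with the same aryl group lacking fluorine. Also open, as far as these compounds go, is how an amine, a carboxylic acid or a nitrile in place of the nitro group would read at this position, and whether the grouping of these four compounds holds beyond this one cell line.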